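This account rests on a few compounds, and the source may have more. Where it says the series, first, only, none or still open, it means among the compounds named here.

Measured compounds and their values in this assay:

compound 1, `CCC(=O)N1CCC(CN(C2Cc3cc(C#N)ccc3N(Cc3cncn3C)C2)S(=O)(=O)c2ccccn2)CC1`: 0.5 10^-6 cm/s
compound 2, `Cn1cnc(S(=O)(=O)N2CCC(CN(C3Cc4cc(C#N)ccc4N(Cc4cncn4C)C3)S(=O)(=O)c3ccccn3)CC2)c1`: 0.1 10^-6 cm/s
compound 3, `CC(=O)N1CCC(CN(C2Cc3cc(C#N)ccc3N(Cc3cncn3C)C2)S(=O)(=O)c2ccccn2)CC1`: 0.5 10^-6 cm/s

In an ADME assay on Caco-2 cells (Homo sapiens) for permeability, in the apical to basolateral direction (on this read-out lower numbers stand for lower permeability and higher numbers for higher permeability), compound 3 stands level with compound 1, the two together giving the highest numbers of the three, while compound 2 gives the lowest. The step of no change at the digits printed from compound 1 to compound 3 (within the scatter) is within the scatter, whereas a 5.0-fold higher number from compound 2 to compound 3 (0.70 log units; beyond the scatter) and a 5.0-fold lower number from compound 1 to compound 2 (0.70 log units; beyond the scatter) are beyond it, both turning on the group carried by the amine nitrogen in the ring.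

Compound 4, `Cn1cncc1CN1CC(N(CC2CCN(C(=O)CC(F)(F)F)CC2)S(=O)(=O)c2ccccn2)Cc2cc(C#N)ccc21`, differs from compound 3 at the acetyl end only: trifluoromethyl in place of hydrogen on a saturated chain carbon bound to a carbonyl carbon.

The step that bears most on this change is no change at the digits printed from compound 1 to compound 3 (within the scatter), a swap of hydrogen for methyl on the same saturated chain carbon bound to a carbonyl carbon, and it moved nothing beyond the scatter. Among the measured compounds shown here, no measured pair carries a trifluoromethyl group, so the data give no direct reading on it. On that basis compound 4 is expected to stay close to compound 3, with at most a small rise, and the step of a 1.4-fold higher number from compound 3 to compound 4 (0.15 log units; within the scatter) is estimated to lie within the scatter. Compound 4 is therefore estimated at 0.7 10^-6 cm/s, within a range of 0.3 10^-6 cm/s to 1.6 10^-6 cm/s.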

Compound 4, apparent permeability: 0.5 10^-6 cm/s
Compound 4: the middle estimate sits 1.4-fold (0.15 log units) above what was measured, and the stated range covers the measured number.
By their numbers in this assay, from the lowest: compound 2; then compounds 1, 3 and 4 (each within the scatter of the next).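

In this assay, among the compounds shown here, the change gives no change at the digits printed from compound 3 to compound 4 (within the scatter) and, set against the methyl compound, no change at the digits printed from compound 1 to compound 4 (within the scatter) and so, with a first reading for a fluorine-bearing group, hydrogen, methyl and trifluoromethyl on this saturated chain carbon bound to a carbonyl carbon all stand level. The trifluoromethyl compound also keeps its distance from the sulfonyl compound, with a 5.0-fold higher number from compound 2 to compound 4 (0.70 log units; beyond the scatter) and, among these four compounds, only the (1-methyl-1H-imidazol-4-yl)sulfonyl group on the amine nitrogen in the ring stands apart, while all three carbonyl-linked groups stay together. Nothing available explains why the number holds steady across these three groups.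

From the compounds shown here alone, it remains open whether this chain carbon would stay as undemanding with an amine, a carboxylic acid, a longer chain or a phenyl ring in place of the trifluoromethyl group. Going by these compounds, it is also open whether a simple methanesulfonyl group on the amine nitrogen would read with compound 2 or with the carbonyl-linked compounds, which would separate the part played by the sulfonyl link from that of the methylimidazole it carries.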